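The source may hold more compounds than are shown below. What is called first, only, known or untested is meant among the compounds shown, and "the series" means these compounds.

Measured so far in an ADME assay on WI-38 cells (Homo sapiens) for inhibition, read by sulforhodamine B assay, with a stated time of 48 h; a higher number here means a weaker inhibitor, a lower number a stronger inhibitor:
- compound 1 `CCCCCCCCCCOc1cc2c(=O)c(C(=O)OCC)cn(C(C)=O)c2cc1OCC`: > 100000 nM
- compound 2 `CCCCCCCCCCOc1cc2c(=O)c(C(=O)OCC)cn(C(=O)CC)c2cc1OCC`: > 100000 nM

Both entries are limits of the assay and not numbers. Compound 2 is known only as the limit > 100000 nM. Across the pair the position is the limit of > 100000 nM in this assay, at which 2 of the 2 values shown sit.

The next member is compound 3 `CCCCCCCCCCOc1cc2c(=O)c(C(=O)OCC)cn(C(=O)N3CCCCC3)c2cc1OCC`. The change from compound 2 is piperidin-1-yl in place of ethyl on a carbonyl carbon. In words, this is piperidin-1-yl in place of ethyl on a carbonyl carbon, so propanoyl becomes (piperidin-1-yl)carbonyl.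

Among the measured compounds shown here, only one measured step bears on this change, namely a step that the two limits leave unreadable from compound 1 to compound 2. That step was also made on the acyl group, as methyl in place of hydrogen on a saturated chain carbon bound to a carbonyl carbon, but it has no readable size. For the measured compounds named here, with compound 2 at > 100000 nM and no sized step to go on, no step beyond the scatter is expected in this assay, and no direction can be expected either.

The estimate amounts to a number no higher from compound 2 to compound 3 (the limit leaves the size open), an expected step that remains tentative. Compound 3 is expected at 100000 nM, with an estimated range of 40000 nM to 200000 nM, and a further report of a limit would fit this expectation.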

Compound 3, half-maximal inhibitory concentration: 8500 nM
Estimate against measurement, compound 3: 12-fold (1.07 log units) above, and the stated range ends above it.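

In this assay, the carbonyl carbon bound to the aromatic nitrogen proves to be a place where the read-out can move: piperidin-1-yl in place of ethyl gives an at least 11-fold lower number from compound 2 to compound 3 (1.07 log units; beyond the scatter), and piperidin-1-yl in place of methyl gives an at least 11-fold lower number from compound 1 to compound 3 (1.07 log units; beyond the scatter). Compound 3 is the first member shown with a number instead of a limit, which gives this position a reading that the methyl and ethyl versions did not; the step between those two cannot be read. Both sized steps start from limits of the assay and not from numbers, so the full size of each remains unknown: the limit of > 100000 nM in this assay, at which 2 of the 3 values shown sit.

Going by these compounds, it remains open whether the change follows from the piperidine ring, from a nitrogen on the carbonyl carbon or from the larger group as such; cyclohexyl, diethylamino or morpholin-4-yl on this carbonyl carbon would separate these readings. On these data alone, the ether chains on the shared core are the same in all three compounds, so the effect of a shorter chain or a free hydroxyl there, alongside piperidin-1-yl, is also open.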